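A few compounds are considered here, and "the series" means these few. Any claim that something is new, unique, unknown or untested is made for them only; others in the source may bear on it.

Three compounds of the series have been run in a functional assay on the whole organism for inhibition, with Rattus norvegicus as the target (a higher number here means that more compound is needed for the effect, a lower number that less compound is needed), and none of them gave a number. Compound 1 `CC1CC/C(=N\Nc2ccccc2)c2nccc(=O)n21` reached only a limit in this assay, reported as > 100 umol/kg. Compound 2 `CC1C/C(=N\Nc2ccccc2)c2ncc(C(=O)O)c(=O)n2C1` likewise gives a limit in this assay, > 320 umol/kg. Compound 3 `CC1CC/C(=N\Nc2ccccc2Cl)c2ncc(C(=O)O)c(=O)n21` is also at a limit in this assay, > 1000 umol/kg. Where compound 3 stands is thus only a limit: each of the three measurements is a limit, (the limit of > 100 umol/kg in this assay, at which 1 of the 3 values shown sits), the limit of > 320 umol/kg in this assay, at which 1 of the 3 values shown sits, and (the limit of > 1000 umol/kg in this assay, at which 1 of the 3 values shown sits), and no step between measured compounds can be read from them, since a pair of limits shows nothing but two limits.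

Compound 4 `CC1CC/C(=N\Nc2ccc(O)cc2)c2ncc(C(=O)O)c(=O)n21` has not yet been measured in this assay. It differs from compound 3 in one place (4-hydroxyphenyl in place of 2-chlorophenyl on an amine nitrogen).

For this step in this assay no measured pair gives a size or a direction, and with every value in the set a limit, no change beyond the scatter can be expected from what is shown. The step from compound 3 to compound 4 is expected to be a number no higher from compound 3 to compound 4 (the limit leaves the size open), that is, no movement beyond the scatter. Compound 4 is estimated in this assay at 1000 umol/kg, within 300 umol/kg to 3000 umol/kg, and is expected most likely to be reported again only as a limit.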

Compound 4, dose for 50% inhibition: > 100 umol/kg
Compound 4 ended at the assay's limit; the forecaster's own chance of this, stated with the estimate: 80%; the middle value lies beyond the limit too.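

Compound 3 and compound 4 both stand only at limits in this assay, and the step between them, 4-hydroxyphenyl in place of 2-chlorophenyl on an amine nitrogen, cannot be read. The compounds shown leave open whether either group changes the dose needed, and whether any compound of the series gives a number in this assay.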